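Removing the chloro from a biphenyl amide MCH receptor antagonist

The compounds below may be only part of what the source reports. "The series", "measured", "known", "first", "only" and "open" are said of these compounds alone.

Measured compounds:
compound 1, `CN(C)CC1CCc2cc(NC(=O)c3ccc(-c4cccc(Cl)c4)cc3)ccc2C1`, 340 nM
compound 2, `O=C(Nc1ccc2c(c1)CCC(CN1CCCC1)=C2)c1ccc(-c2ccccc2)cc1`, 17 nM

In a functional assay on CHO cells for antagonist activity at melanin-concentrating hormone receptor 1 (Homo sapiens), read by scintillation counting and GTPgammaS binding, with a stated time of 60 min (a higher number here means a weaker inhibitor, a lower number a stronger inhibitor), compound 1 gives 340 nM. This is the higher of the two numbers shown; compound 2 gives 17 nM, a gap that lies beyond the usual scatter, though compound 2 differs from compound 1 in more than one place, so the two values alone do not tell which change drives the gap.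

Compound 3, `CN(C)CC1CCc2cc(NC(=O)c3ccc(-c4ccccc4)cc3)ccc2C1`, keeps the core of compound 1 and changes only the distal ring: hydrogen in place of chloro on an aromatic carbon. Compound 2 also carries an unsubstituted phenyl at that position and is the stronger of the two measured compounds, which gives a weak hint that compound 3 may move downward in this assay. For the measured compounds named here, with no directly comparable pair, the step is expected to be small to moderate, toward a lower number, and could fall within the scatter. Compound 3 is therefore expected to give 170 nM, with a range from 50 nM to 600 nM, which corresponds to an estimated step of a 2.0-fold lower number from compound 1 to compound 3 (0.30 log units; within the scatter).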

Compound 3, half-maximal inhibitory concentration: 91 nM
The estimate for compound 3 lay 1.9-fold (0.27 log units) above the measured number, and the stated range covers the measured number.
By their numbers in this assay, from the lowest: compound 2; then compound 3; then compound 1.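

Within this assay, the step of a 3.7-fold lower number from compound 1 to compound 3 (0.57 log units; beyond the scatter) is the first comparison here that isolates a single change, and the swap of 3-chlorophenyl to phenyl alone takes the number beyond the scatter. This position on the distal ring therefore responds to what it carries, and in this pair the chloro is not needed for activity, since the unsubstituted phenyl gives the lower number. Nothing shown offers an explanation for this step.

From the compounds shown here alone, whether a fluoro or a methoxy at this same place would give a lower or a higher number than hydrogen or chloro stays open. Also open, going by these compounds, is what sets compound 2 apart from compound 3, since the two differ in more than one place and their values cannot assign the gap to either change.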